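A few compounds are considered here, and "the series" means these few. Any claim that something is new, unique, unknown or untested is made for them only; others in the source may bear on it.

In a functional assay, read by spectrophotometry, with a stated time of 30 min (a higher number here means a weaker inhibitor, a lower number a stronger inhibitor), compound 1 `CC(C)(C)c1cc(/C=C/C(=O)NCCC2CCN(Cc3ccccc3F)CC2)cc(C(C)(C)C)c1O` gives 55900 nM and compound 2 `CC(C)(C)c1cc(/C=C/C(=O)NCCC2CCN(Cc3ccc(Br)cc3)CC2)cc(C(C)(C)C)c1O` gives 85600 nM so these two values lie within the usual scatter of each other. Compound 3 `CC(C)(C)c1cc(/C=C/C(=O)NCCC2CCN(Cc3ccc(C#N)cc3)CC2)cc(C(C)(C)C)c1O` differs from compound 2 in one group: cyano in place of bromo on an aromatic carbon with cyano in place of bromo on an aromatic carbon. Going by the values given here, the only measured step on that ring is a 1.5-fold higher number from compound 1 to compound 2 (0.19 log units; within the scatter) and it stays within the scatter. One small step is thin evidence, but it gives no reason to expect a larger one in this assay here. The estimated change is a 1.2-fold lower number from compound 2 to compound 3 (0.09 log units; within the scatter) and is expected to stay within the scatter. Compound 3 is expected to read 70000 nM with 30000 nM to 150000 nM as its estimated range.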

Compound 3, half-maximal inhibitory concentration: 79500 nM
Compound 3: the middle estimate sits 1.1-fold (0.06 log units) below what was measured; measured number inside the range.
By their numbers in this assay, from the lowest: compounds 1, 3 and 2 (each within the scatter of the next).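

In this assay, cyano in place of bromo, para to a large group, gives a 1.1-fold lower number from compound 2 to compound 3 (0.03 log units; within the scatter). Going by these compounds alone, this is the first comparison of two groups at this same position, and a nitrile and a halogen read alike here. The 4-cyanophenyl in place of the 2-fluorophenyl gives a 1.4-fold higher number from compound 1 to compound 3 (0.15 log units; within the scatter), so all three compounds remain within the scatter of one another, and no separate measurement bears on this result. As far as these compounds go, whether an amine or a carboxylic acid at this position would shift the number beyond the scatter remains open.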